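Working notes: trifluoromethyl to hydrogen on the phenyl ring

The source may hold more compounds than are shown below. What is called first, only, known or untested is meant among the compounds shown, and "the series" means these compounds.

Measured in a functional assay on the whole organism (3LL cells, lung) for antiproliferative activity against 3LL cell line (Mus musculus), at a dose of 15 mg/kg by the oral route; on this read-out higher numbers stand for more inhibition at the one dose given (going by the name of the read-out) and lower numbers for less inhibition:
compound 1 `CN(C)c1nsc(-c2ccc(N3CCN(c4cccc(C(F)(F)F)c4)CC3)nn2)n1`: 39%
compound 2 `FC(F)(F)c1cccc(N2CCN(C3CCN(c4ccc(-c5ncns5)nn4)CC3)CC2)c1`: 54%
compound 3 `CN(C)c1nsc(-c2ccc(N3CCC(N4CCN(c5cccc(C(F)(F)F)c5)CC4)CC3)nn2)n1`: 25%

Compound 1 stands second of the three numbers; compound 2 lies above it and compound 3 below it, both gaps beyond the scatter. Among the measured compounds shown here, the one measured single-point step, a number 29 percentage points lower from compound 2 to compound 3 (beyond the scatter), concerns dimethylamino in place of hydrogen on the shared core and has no bearing on the change considered here.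

Compound 4 `CN(C)c1nsc(-c2ccc(N3CCN(c4ccccc4)CC3)nn2)n1` differs from compound 1 by hydrogen in place of trifluoromethyl on an aromatic carbon; 3-(trifluoromethyl)phenyl becomes phenyl. For the measured compounds named here, no measured pair isolates this change, so no step beyond the scatter in this assay is expected. The step of a number 4 percentage points lower from compound 1 to compound 4 (within the scatter) is expected to stay within the scatter. Compound 4 is estimated at 35%, with a range from 15% to 55%.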

Compound 4, a percentage reported as inhibition, in the whole organism at one dose (the size of the read-out at that dose, not a potency): 13%
Estimate against measurement, compound 4: 22 percentage points above; the measured number lies below the stated range.
By their numbers in this assay, from the lowest: compound 4; then compound 3; then compound 1; then compound 2.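

In this assay, among the compounds shown here, hydrogen in place of trifluoromethyl on an aromatic carbon gives a number 26 percentage points lower from compound 1 to compound 4 (beyond the scatter), the only measured step at this position. The number on this read-out therefore depends on the trifluoromethyl group of 3-(trifluoromethyl)phenyl, at least on the core of compound 1. Nothing available explains the size of this step.

From the compounds shown here alone, whether a chlorine atom, a methoxy group or a nitrile in the same place would retain the number of compound 1 stays open. So does whether removing trifluoromethyl has a similar effect on the cores of compound 2 and compound 3.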